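Two cores, one shared methyl-for-hydrogen change on the urea

This account rests on a few compounds, and the source may have more. Where it says the series, first, only, none or still open, it means among the compounds named here.

Measured so far:
compound 1 `Cc1cccc(Oc2ccc(C#N)cc2S(=O)(=O)NC(=O)NC(C)C)c1` gives 2380 nM
compound 2 `Cc1cccc(Oc2ccc(C#N)cc2S(=O)(=O)NC(=O)NC(C)(C)C)c1` gives 1050 nM
compound 3 `Cc1ccccc1Nc1ccc(C#N)cc1S(=O)(=O)NC(=O)NC(C)C` gives 7240 nM

In a functional assay on HEK293 cells for antagonist activity at thromboxane A2 receptor (Homo sapiens), read by fluorescence and calcium flux (on this read-out higher numbers stand for weaker inhibition and lower numbers for stronger inhibition), compound 1 gives 2380 nM, and compound 2 gives 1050 nM. The change between them is methyl in place of hydrogen on a saturated chain carbon bound to an amide-type nitrogen and two saturated chain carbons, and it made a step of a 2.3-fold lower number from compound 1 to compound 2 (0.36 log units; beyond the scatter). The two cores differ by (2-methylphenyl)amino in place of 3-methylphenoxy on an aromatic carbon, which made a step of a 3.0-fold higher number from compound 1 to compound 3 (0.48 log units; beyond the scatter); compound 3 gives 7240 nM, the highest number among the three.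

Compound 4 `Cc1ccccc1Nc1ccc(C#N)cc1S(=O)(=O)NC(=O)NC(C)(C)C` is not yet measured. It differs from compound 3 by methyl in place of hydrogen on a saturated chain carbon bound to an amide-type nitrogen and two saturated chain carbons, the same change, at the same place, as that from compound 1 to compound 2. Resting on that single earlier step, a 2.3-fold lower number from compound 1 to compound 2 (0.36 log units; beyond the scatter), the step from compound 3 to compound 4 is expected to be of like size, namely a 2.3-fold lower number from compound 3 to compound 4 (0.35 log units; beyond the scatter). Compound 4 is therefore estimated at 3200 nM, with a likely range from 1500 nM to 7000 nM.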

Compound 4, half-maximal inhibitory concentration: 2750 nM
Beside the measured number, compound 4's estimate is 1.2-fold (0.07 log units) above it; measured number inside the range.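

On the core of compound 3, methyl in place of hydrogen gave a 2.6-fold lower number from compound 3 to compound 4 (0.42 log units; beyond the scatter) in this assay, and this step matches the earlier one: the same change on two cores in this assay, a 2.3-fold lower number (0.36 log units; beyond the scatter) from compound 1 to compound 2 and a 2.6-fold lower number (0.42 log units; beyond the scatter) from compound 3 to compound 4, 1.2-fold (0.07 log units) apart, within the scatter of two such steps. With the tert-butyl urea in place, (2-methylphenyl)amino in place of 3-methylphenoxy gave a 2.6-fold higher number from compound 2 to compound 4 (0.42 log units; beyond the scatter), which likewise matches the step seen with the isopropyl urea: the same change on two cores in this assay, a 3.0-fold higher number (0.48 log units; beyond the scatter) from compound 1 to compound 3 and a 2.6-fold higher number (0.42 log units; beyond the scatter) from compound 2 to compound 4, 1.2-fold (0.07 log units) apart, within the scatter of two such steps. Across these four compounds the two changes therefore carry over from one core to the other without a measurable difference, but this rests on a single pair of cores in one assay and does not show that the change would carry to any other core.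

As far as these compounds go, whether a longer chain or a cyclopropyl group in place of tert-butyl would shift the number further remains open. So does whether the same step would hold with a benzyl group in place of (2-methylphenyl)amino.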